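A few compounds are considered here, and "the series" means these few. Any claim that something is new, unique, unknown or untested is made for them only; others in the source may bear on it.

Measured so far:
compound 1, `CCCCOc1ccc(C[C@H]2C(=O)OC[C@@H]2Cc2ccccc2)cc1`: 23000 nM
compound 2, `O=C1OC[C@H](Cc2ccccc2O)[C@H]1Cc1ccc(Cl)c(Cl)c1`: 33000 nM

Both numbers come from a functional assay on HL-60 cells (Homo sapiens) for cytotoxicity, read by WST assay, with a stated time of 48 h; on this read-out lower numbers stand for an effect already at smaller amounts and higher numbers for an effect only at larger amounts of compound. Of the two, compound 2 carries the highest number; compound 1 sits nearest to it, and the gap between them lies within the scatter, so the two cannot be told apart on these measurements.

Compound 3, `Cc1ccc(C[C@H]2COC(=O)[C@@H]2Cc2ccc(Cl)c(Cl)c2)cc1`, remains to be measured in this assay. It differs from compound 2 in one place: 4-methylphenyl in place of 2-hydroxyphenyl on a saturated chain carbon bound to a saturated ring carbon. Going by the values given here, no measured pair shows the effect of such a change, so the size of the step is open. Both measured compounds give high numbers, and nothing in hand points in either direction; the expected step is small, not beyond the scatter.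

Compound 3 is accordingly expected to give 30000 nM in this assay, with a range from 12000 nM to 75000 nM. The estimated step is then a 1.1-fold lower number from compound 2 to compound 3 (0.04 log units; within the scatter), within the scatter.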

Compound 3, half-maximal effective concentration: 19000 nM
Estimate against measurement, compound 3: 1.6-fold (0.20 log units) above, within the range that was stated.
By their numbers in this assay, from the lowest: compounds 3, 1 and 2 (each within the scatter of the next).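

In this assay, going by these compounds alone, the pair gives the first one-place step: 4-methylphenyl in place of 2-hydroxyphenyl on a saturated chain carbon bound to a saturated ring carbon is a 1.7-fold lower number from compound 2 to compound 3 (0.24 log units; within the scatter). At this position, then, the read-out does not separate the two groups, even though the hydrogen-bond donor and acceptor counted on 2-hydroxyphenyl are absent from 4-methylphenyl. No independent measurement bears on this result.

Still open, from the compounds shown here alone, is whether a different group at this place, such as an amine or a carboxylic acid, would give a step beyond the scatter. Also open, going by these compounds, is whether the step read from this single pair holds on the core of compound 1.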